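Ethyl to isopropyl on the azole nitrogen of compound 2

This account rests on a few compounds, and the source may have more. Where it says the series, first, only, none or still open, it means among the compounds named here.

Measured so far:
compound 1 `Cc1nc(-c2ccccc2NCC2=NCCN2)n(C)n1` gives 0% in a functional assay with Alpha-1B adrenergic receptor (Homo sapiens) as the target, read by calcium flux; on this read-out higher numbers stand for larger maximal responses and lower numbers for smaller maximal responses
compound 2 `CCn1ncnc1-c1ccccc1NCC1=NCCN1` gives 94%
compound 3 `Cc1ccc(-c2ccccc2NCC2=NCCN2)n1C` gives 0%

Compound 2 stands highest of the three numbers; compound 1 and compound 3 both sit far lower, each beyond the scatter. Compound 4 `CC(C)n1ncnc1-c1ccccc1NCC1=NCCN1` is not yet measured. The change from compound 2 to compound 4 is methyl in place of hydrogen on a saturated chain carbon bound to an aromatic nitrogen and a saturated chain carbon. Within the data shown here, no measured pair shows the same change, so the size of the step is open. Since compound 2 gives 94%, the step is expected to be small or none beyond the scatter, with some risk of a fall. Compound 4 is estimated at 80%, between 40% and 100%, an expected step of a number 14 percentage points lower from compound 2 to compound 4 (beyond the scatter).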

Compound 4, largest response reached (reported as maximal response), in percent of the reference or control that the assay uses: 0%
Estimate against measurement, compound 4: 80 percentage points above, outside the stated range (below it).
By their numbers in this assay, from the lowest: compounds 1, 3 and 4 (each within the scatter of the next); then compound 2.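

Among these compounds, this is the first step that changes one place only, and it is steep: ethyl to isopropyl gives a number 94 percentage points lower from compound 2 to compound 4 (beyond the scatter) in this assay. A single added methyl on the saturated chain carbon bound to the aromatic nitrogen is therefore enough to separate a full response from none, so this position tolerates little change in this read-out. Nothing available explains the fall.

From the compounds shown here alone, it remains open whether a longer chain such as n-propyl, or a cyclopropyl ring, in place of the ethyl keeps the response of compound 2. A methoxyethyl chain at this place is equally untested by the compounds shown.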